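The source may report more compounds than this note shows. Statements on the series, on what has been measured and on what is new or still open speak of the compounds shown alone.

Measured in an ADME assay on cells (Peritoneal macrophage, Mus musculus) for cytotoxicity, read by CCK-8 assay, with a stated time of 24 h; on this read-out lower numbers stand for higher toxicity in this test and higher numbers for lower toxicity in this test:
compound 1 `COc1ccc(S(=O)(=O)N(CC(N)=O)c2ccc(N(CC(N)=O)S(=O)(=O)c3ccc(SCCCN=C=S)cc3)c3ccccc23)cc1`: > 10000 nM (a limit)
compound 2 `COc1ccc(S(=O)(=O)N(CC(N)=O)c2ccc(N(CC(N)=O)S(=O)(=O)c3ccc(SCCCCN=C=S)cc3)c3ccccc23)cc1`: > 10000 nM (a limit)

Compound 2 gives only a limit, > 10000 nM, and no number. This is the limit of > 10000 nM in this assay, at which 2 of the 2 values shown sit.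

Compound 3 `COc1ccc(S(=O)(=O)N(CC(N)=O)c2ccc(N(CC(N)=O)S(=O)(=O)c3ccc(SCCCCCN=C=S)cc3)c3ccccc23)cc1` is not yet measured. It differs from compound 2 as follows: a group of 4 heavy atoms (2 carbon, 1 nitrogen, 1 sulfur; no ring) in place of a group of 3 heavy atoms (1 carbon, 1 nitrogen, 1 sulfur; no ring), on a saturated chain carbon, four bonds along the chain from a sulfur. Among the measured compounds shown here, the single measured step of this kind is a step that the two limits leave unreadable from compound 1 to compound 2, and it has no readable size, so it offers neither a size nor a direction to carry forward. For the measured compounds named here, the only guide is that compound 1 and compound 2 share one limit. The expected step is a step that the limit leaves unreadable from compound 2 to compound 3, which means no change beyond the scatter in either direction. For compound 3 the estimate is 15000 nM, with an expected range of 6000 nM to 40000 nM, and the result is expected to be most likely reported again as a limit.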

Compound 3, half-maximal cytotoxic concentration: > 10000 nM
Compound 3: only a limit was reported; the forecaster's own chance of this, stated with the estimate: 85%; the middle value is on the limit's open side.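

In this assay compound 3 gives > 10000 nM, a limit, so no step among compound 1, compound 2 and compound 3 can be read: the limit of > 10000 nM in this assay, at which 3 of the 3 values shown sit.

The compounds shown leave open whether chain length changes the read-out at all, and at what concentration any of them reaches half-maximal cytotoxicity.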